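This account rests on a few compounds, and the source may have more. Where it says the series, first, only, none or still open, it means among the compounds named here.

Compound 1 `CC(C)OC(=O)N1CCC(Oc2ncnc3c2CCN3c2ccc(S(C)(=O)=O)cc2F)CC1` reaches 91% in a functional assay on CHO-K1 cells with Glucose-dependent insulinotropic receptor (Homo sapiens) as the target, read by a luciferase reporter, with a stated time of 5 h; on this read-out lower numbers stand for smaller maximal responses and higher numbers for larger maximal responses. Compound 2 `CCS(=O)(=O)N1CCC(Oc2ncnc3c2CCN3c2ccc(S(C)(=O)=O)cc2F)CC1` gives 51% in this assay, the lowest of the two numbers, placed below compound 1 by a number 40 percentage points lower from compound 1 to compound 2 (beyond the scatter). Compound 3 `CC(C)c1noc(N2CCC(Oc3ncnc4c3CCN4c3ccc(S(C)(=O)=O)cc3F)CC2)n1` differs from compound 2 by 3-isopropyl-1,2,4-oxadiazol-5-yl in place of ethylsulfonyl on an amine nitrogen in a ring. Within the data shown here, the only measured step also replaces the group on this same ring nitrogen and was large, so a step of comparable size is plausible here; no step toward this oxadiazolyl group exists, and its direction stays open. Compound 3 is expected to reach 75% in this assay, within 45% to 105%, an estimated step of a number 24 percentage points higher from compound 2 to compound 3 (beyond the scatter).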

Compound 3, largest response reached (reported as percent of maximum), in percent of the reference or control that the assay uses: 124%
For compound 3 the middle estimate is 49 percentage points below the measured one; the measured number lies above the stated range.
By their numbers in this assay, from the lowest: compound 2; then compound 1; then compound 3.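

Putting 3-isopropyl-1,2,4-oxadiazol-5-yl in place of ethylsulfonyl on the amine nitrogen in a ring gives a number 73 percentage points higher from compound 2 to compound 3 (beyond the scatter) and in place of isopropoxycarbonyl gives a number 33 percentage points higher from compound 1 to compound 3 (beyond the scatter) in this series. The earlier pair showed only a fall in this assay at this nitrogen; this result shows that a five-membered aromatic ring here can also lift the response above that of both other groups. Nothing available explains this order of the three groups.

As far as these compounds go, it remains open how much of the gain rests on the ring itself and how much on its isopropyl group. Methyl or tert-butyl in place of that isopropyl would bear on this.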